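Aminophenyl in place of the ester arm: expected cytotoxicity

The source may report more compounds than this note shows. Statements on the series, on what has been measured and on what is new or still open speak of the compounds shown alone.

Measured compounds:
- compound 1, `Cc1ccccc1-c1nn(-c2ccc(C(F)(F)F)cc2)cc1CNCCN1CCN(C)CC1`: 11000 nM
- compound 2, `Cc1ccccc1-c1nn(-c2ccc(Cl)cc2)cc1CNCCN1CCN(C)CC1`: 17000 nM
- compound 3, `CCOC(=O)Cn1cc(CNCCN2CCN(C)CC2)c(-c2ccccc2C)n1`: > 20000 nM

All three were tested in an ADME assay on Huh-7 cells (Homo sapiens) for cytotoxicity; on this read-out lower numbers stand for higher toxicity in this test and higher numbers for lower toxicity in this test. For the measured compounds named here, the value for compound 3 is a limit of the assay, not a number, and compound 3 is the one compound sitting at the limit of > 20000 nM in this assay, at which 1 of the 3 values shown sits. Compound 1 and compound 2 carry an aryl group on the ring nitrogen where compound 3 carries the ester arm, and the step of a 1.5-fold higher number from compound 1 to compound 2 (0.19 log units; within the scatter) is small. Toward compound 3 the steps of an at least 1.8-fold higher number from compound 1 to compound 3 (0.25 log units; that floor lies within the scatter) and an at least 1.1-fold higher number from compound 2 to compound 3 (0.07 log units; that floor lies within the scatter) give only floors, which also stay within the scatter, so all three compounds lie close together on this read-out.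

Compound 4, `Cc1ccccc1-c1nn(-c2ccc(N)cc2)cc1CNCCN1CCN(C)CC1`, differs from compound 3 in one place: 4-aminophenyl in place of (ethoxycarbonyl)methyl on an aromatic nitrogen. Going by the values given here, no measured step swaps an ester arm for an aminophenyl group. What is known is that compounds with an aryl group on this nitrogen, compound 1 and compound 2, sit near compound 3. The step of an at least 1.1-fold lower number from compound 3 to compound 4 (0.04 log units; that floor lies within the scatter) is therefore expected to be small, with no direction beyond the scatter. Compound 4 is estimated at 18000 nM, with a range from 8000 nM to 40000 nM.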

Compound 4, half-maximal cytotoxic concentration: > 20000 nM
Compound 4 ended at the assay's limit; the forecaster's own chance of this, stated with the estimate: 45%; at least 1.1-fold (0.04 log units) between middle value and limit.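

In this assay, compound 4 now shows that an aryl group on the ring nitrogen can also sit at the assay's limit, so reaching that limit does not depend on the ester arm of compound 3: the limit of > 20000 nM in this assay, at which 2 of the 4 values shown sit. Within the aryl series, amino in place of chloro gives an at least 1.1-fold higher number from compound 2 to compound 4 (0.07 log units; that floor lies within the scatter), and amino in place of trifluoromethyl gives an at least 1.8-fold higher number from compound 1 to compound 4 (0.25 log units; that floor lies within the scatter), so both steps are only floors and neither shows a change beyond the scatter. Compound 3 and compound 4 both carry limits rather than numbers, so the step between them cannot be read.

From the compounds shown here alone, how far the true values of these two compounds lie past the limit stays open. Also open, going by these compounds, is whether a carboxylic acid or a methoxy group in place of the amino group would leave a compound at that limit.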